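Working notes: from compound 2 to compound 3

The compounds below may be only part of what the source reports. "The series", "measured", "known", "first", "only" and "open" are said of these compounds alone.

Values measured in an ADME assay on MRC5 cells (Homo sapiens) for cytotoxicity, read by fluorescence and resazurin assay, with a stated time of 3 days (on this read-out lower numbers stand for an effect already at smaller amounts and higher numbers for an effect only at larger amounts of compound), are as follows
- compound 1 `O=C1C=CC(O)(c2cc3ccc(F)cc3n2S(=O)(=O)c2ccccc2)C=C1` gives 170 nM
- compound 2 `O=C1C=CC(O)(c2cc3ccccc3n2S(=O)(=O)c2ccccc2)C=C1` gives 110 nM

Compound 2 at 110 nM lies within the scatter of compound 1, so the two numbers show no order. Compound 3 `CCOC(=O)Nc1ccc(S(=O)(=O)n2c(C3(O)C=CC(=O)C=C3)cc3ccccc32)cc1` differs from compound 2 by (ethoxycarbonyl)amino in place of hydrogen on an aromatic carbon in the form of (ethoxycarbonyl)amino in place of hydrogen on an aromatic carbon, para to a large group. Within the data shown here, the only measured step is a 1.5-fold lower number from compound 1 to compound 2 (0.19 log units; within the scatter) and it is hydrogen in place of fluoro. Among the measured compounds shown here, no measured compound carries a group other than hydrogen at the place now changed, so the direction remains poorly defined. With that single small step as the guide, only a modest change is expected in this assay and a slightly higher number is tentatively favoured. The estimated move is a 1.6-fold higher number from compound 2 to compound 3 (0.21 log units; within the scatter) and it is expected to stay modest. Compound 3 is expected at 180 nM with an estimated range from 60 nM to 500 nM in this read-out.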

Compound 3, half-maximal effective concentration: 86 nM
The estimate for compound 3 lay 2.1-fold (0.32 log units) above the measured number; measured number inside the range.
By their numbers in this assay, from the lowest: compounds 3, 2 and 1 (each within the scatter of the next).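

Up to compound 2, only hydrogen stood at this place, on an aromatic carbon of a six-membered aromatic ring of carbon only, para to a large group. Compound 3 shows that (ethoxycarbonyl)amino, with 6 heavy atoms and no ring, can stand there without the number in this assay leaving the scatter, at a 1.3-fold lower number from compound 2 to compound 3 (0.11 log units; within the scatter). This is a single replacement at this place, so it shows that one group is accommodated in this read-out and sets no trend, and no measured data bear on why the number holds.

From the compounds shown here alone, whether an amine, a carboxylic acid or a longer chain at this place would also stay within the scatter remains open. Also open, going by these compounds, is whether (ethoxycarbonyl)amino would behave the same way in the fluoro-bearing core of compound 1.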